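Diacylglyceryl cysteine series: agonist potency at Toll-like receptor 2

The compounds below may be only part of what the source reports. "The series", "measured", "known", "first", "only" and "open" are said of these compounds alone.

Measured so far:
- compound 1 `CCCCCCCCCCCCCCCC(=O)OC[C@H](CSC[C@H](N)C(=O)NCC(=O)OC(C)C)OC(=O)CCCCCCCCCCCCCCC` — 0.45 nM
- compound 2 `CCCCCCCCCCCCCCCC(=O)OC[C@H](CSC[C@H](NC(=O)CC[C@H](N)C(=O)O)C(=O)NCC(=O)OC(C)C)OC(=O)CCCCCCCCCCCCCCC` — > 1000 nM
- compound 3 `CCCCCCCCCCCCCCCC(=O)OCCCSC[C@H](N)C(=O)N[C@@H](CO)C(=O)OC` — > 1000 nM

Within the data shown here, in a functional assay on HEK293 cells for agonist activity at Toll-like receptor 2 (Homo sapiens), read by spectrophotometry, with a stated time of 12 h (a lower number here means that less compound is needed, a higher number that more compound is needed for the effect), compound 1 gives 0.45 nM, the only numeric value in the set. For compound 2 the assay reports only a limit, > 1000 nM. For compound 3 the assay likewise reports only a limit, > 1000 nM. Among the measured compounds shown here, the one step available, an at least 2200-fold higher number from compound 1 to compound 2 (3.34 log units; beyond the scatter), runs up to the limit of > 1000 nM in this assay, at which 2 of the 3 values shown sit.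

Compound 4 `CCCCCCCCCCCCCCCC(=O)OC[C@H](CSCC[C@H](N)C(=O)N[C@@H](CO)C(=O)O)OC(=O)CCCCCCCCCCCCCCC` is not yet measured. It differs from compound 1 by 2-amino-2-((1-carboxy-2-hydroxyethyl)carbamoyl)ethyl in place of amino(((isopropoxycarbonyl)methyl)carbamoyl)methyl on a saturated chain carbon bound to a sulfur. For the measured compounds named here, the shared diacylglycerol core and the free amine are kept, so the measured step from compound 1 to compound 2, which removes the free amine, does not directly apply; no measured step covers chain lengthening at the sulfur-bound carbon or the change of the ester to a carboxylic acid. Compound 3 only shows that a different lipid part with a serine ester sits at the limit. A moderate loss is therefore expected for compound 4, a 22-fold higher number from compound 1 to compound 4 (1.35 log units; beyond the scatter), with wide uncertainty; the estimate for compound 4 is 10 nM (range 1 nM to 300 nM).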

Compound 4, half-maximal effective concentration: > 1000 nM
Compound 4: a limit, no number; the forecaster's own chance of this, stated with the estimate: 20%; middle value at least 100-fold (2.00 log units) from the limit.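

In this assay compound 4 gives > 1000 nM, which is a limit and not a number. With the shared core and the free amine both retained, 2-amino-2-((1-carboxy-2-hydroxyethyl)carbamoyl)ethyl in place of amino(((isopropoxycarbonyl)methyl)carbamoyl)methyl on a saturated chain carbon bound to a sulfur gives an at least 2200-fold higher number from compound 1 to compound 4 (3.34 log units; beyond the scatter). The core and free amine together are therefore not sufficient for a measurable value, and this change takes the series back to the same ceiling: the limit of > 1000 nM in this assay, at which 3 of the 4 values shown sit.

The change combines a longer chain, a carboxylic acid in place of the isopropyl ester, and a hydroxymethyl group on the amino acid unit, and the compounds shown do not separate these. Open, from the compounds shown here alone, is whether the longer chain with the isopropyl ester retained, or a carboxylic acid on the chain of compound 1, would keep a measurable value.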